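The source may hold more compounds than are shown below. What is called first, only, known or untested is meant among the compounds shown, and "the series" means these compounds.

Going by the values given here, in a toxicity assay on CCRF-CEM cells (Homo sapiens) for cytotoxicity (a higher number here means that more compound is tolerated, a lower number that less compound is tolerated), compound 2 `CCc1cccc2c1nc(-c1c(F)cccc1F)n2Cc1c(F)cccc1F` gives 26.1 uM, the only number among the values shown. Compound 1 `Cc1cccc2c1nc(-c1c(F)cccc1F)n2Cc1c(F)cccc1F` gives > 100 uM, which is a limit of the assay rather than a number. Among the compounds with values here, the only measured step is an at least 3.8-fold lower number from compound 1 to compound 2 (0.58 log units; beyond the scatter), from methyl to ethyl at the same group. Compound 3 `Nc1cccc2c1nc(-c1c(F)cccc1F)n2Cc1c(F)cccc1F` differs from compound 2 by amino in place of ethyl on an aromatic carbon. Since compound 1 sits at the limit of > 100 uM in this assay, at which 1 of the 2 values shown sits, the reverse movement, from ethyl to a smaller amino group, is expected to raise the number: compound 3 is expected to show a 2.3-fold higher number from compound 2 to compound 3 (0.36 log units; beyond the scatter). The estimate for compound 3 is 60 uM, between 20 uM and 200 uM.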

Compound 3, half-maximal toxic concentration: 26.3 uM
The estimate for compound 3 lay 2.3-fold (0.36 log units) above the measured number; measured number inside the range.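

Ethyl and amino on this aromatic carbon cannot be told apart in this assay, which gives a 1.0-fold higher number from compound 2 to compound 3 (0.00 log units; within the scatter). Amino, with its single heavy atom, does not read like methyl, and the data give an at least 3.8-fold lower number from compound 1 to compound 3 (0.58 log units; beyond the scatter). Compound 1 alone stands at a limit of the assay, not at a number: the limit of > 100 uM in this assay, at which 1 of the 3 values shown sits.

The compounds shown leave open how a hydroxyl, a methoxy group or a longer chain such as propyl would read on this aromatic carbon. They also leave open how far compound 1 truly lies from the other two compounds.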